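Swapping the acyl aryl group on a thiazolyl urea

The source may report more compounds than this note shows. Statements on the series, on what has been measured and on what is new or still open speak of the compounds shown alone.

Measured compounds:
compound 1 `Cc1nc(N(C)C(=O)NC(=O)c2c(F)cccc2F)sc1C(=O)N/N=C/c1ccc(C(F)(F)F)cc1` — 30.6 ug/mL
compound 2 `CN(C(=O)NC(=O)c1ccc([N+](=O)[O-])cc1)c1nc(C(F)(F)F)c(C(=O)N/N=C/c2cccc(C(F)(F)F)c2)s1` — 4.39 ug/mL
compound 3 `CN(C(=O)NC(=O)c1ccc([N+](=O)[O-])cc1)c1nc(C(F)(F)F)c(C(=O)N/N=C/c2ccc([N+](=O)[O-])cc2)s1` — 9.24 ug/mL

In a functional assay on MCF7 cells (Homo sapiens) for inhibition, read by MTT assay, with a stated time of 72 h (on this read-out lower numbers stand for stronger inhibition and higher numbers for weaker inhibition), compound 2 gives the lowest number of the three, so it is the strongest inhibitor shown. Compound 3 is nearest to it, with a 2.1-fold higher number from compound 2 to compound 3 (0.32 log units; beyond the scatter), and compound 1 is furthest, its number standing much higher than that of compound 2.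

The unmeasured compound 4 `CN(C(=O)NC(=O)c1c(F)cccc1F)c1nc(C(F)(F)F)c(C(=O)N/N=C/c2cccc(C(F)(F)F)c2)s1` differs from compound 2 in one place: 2,6-difluorophenyl in place of 4-nitrophenyl on a carbonyl carbon. Among the compounds with values here, no measured pair shows exactly this change. Within the data shown here, the only single-point step at hand, a 2.1-fold higher number from compound 2 to compound 3 (0.32 log units; beyond the scatter), concerns the group on the carbon with a double bond to nitrogen, not the carbonyl carbon, so it bears on compound 4 only indirectly, as a sign that exchanging one aryl group for another moves the number modestly. Compound 1 carries the 2,6-difluorophenyl on its carbonyl but also differs from compound 2 elsewhere, so its high number cannot be assigned to that group alone.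

Compound 4 is therefore expected to land between compound 2 and compound 1, with a 2.3-fold higher number from compound 2 to compound 4 (0.36 log units; beyond the scatter) as the estimated step. The expected value for compound 4 in this assay is 10 ug/mL, within a range from 3.5 ug/mL to 30 ug/mL.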

Compound 4, half-maximal inhibitory concentration: 21.8 ug/mL
Compound 4: middle estimate off by 2.2-fold (0.34 log units), on the low side; measured number inside the range.
By their numbers in this assay, from the lowest: compound 2; then compound 3; then compounds 4 and 1 (each within the scatter of the next).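

In this assay the aryl group on the carbonyl carbon can now be read directly: with the rest of the molecule unchanged, 2,6-difluorophenyl in place of 4-nitrophenyl gives a 5.0-fold higher number from compound 2 to compound 4 (0.70 log units; beyond the scatter) and this step lies beyond the scatter, so the number responds to the group at this position. Compound 1 also carries 2,6-difluorophenyl, but it differs from compound 2 in more than one place, so its number could not be tied to that group alone, whereas the pair of compound 2 and compound 4 isolates this single change. No measurement shown here explains the step, so it cannot be said whether losing the nitro group or gaining the two fluorines matters more.

From the compounds shown here alone, whether a plain phenyl or a 4-cyanophenyl on this carbonyl carbon would give a number closer to that of compound 2 or of compound 4 remains open. Also open, going by these compounds, is whether this swap would move the number in the same direction and by a similar amount with a different aryl group on the carbon with a double bond to nitrogen, such as the 4-nitrophenyl of compound 3.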